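The compounds below may be only part of what the source reports. "The series", "measured", "known", "first", "only" and "open" are said of these compounds alone.

Measured in a functional assay on HeLa cells (Homo sapiens) for cytotoxicity, read by MTT assay; a lower number here means a stronger inhibitor, a higher number a weaker inhibitor:
- compound 1 `COc1cc(OC)c(C(=O)/C=C/c2ccc(O)cc2)c(O)c1CC=C(C)C`: 11800 nM
- compound 2 `COc1cc(O)c(C(=O)/C=C/c2ccc(O)cc2)c(O)c1CC=C(C)C`: 28300 nM

Of these two, compound 2 has the higher number at 28300 nM, which makes it the weaker inhibitor of the pair in this assay. Compound 1 stands at 11800 nM.

Compound 3 `COc1cc(O)c(C(=O)/C=C/c2ccc(O)cc2)c(OC)c1CC=C(C)C` differs from compound 2 in one place: methyl in place of hydrogen on an oxygen on an aromatic ring. This is methyl in place of hydrogen on an oxygen on an aromatic ring, or hydroxy to methoxy. Among the compounds with values here, only one measured step bears on it: a 2.4-fold higher number from compound 1 to compound 2 (0.38 log units; beyond the scatter). That step puts hydrogen in place of methyl, so it runs opposite to the present change, and read backwards it gives a lower number on methylation. However, compound 3 carries its methyl on a different oxygen from compound 1, and no measurement yet shows how that oxygen behaves. A modest move toward a lower number is therefore expected, smaller than the measured step and with wide uncertainty. The expected change is a 1.9-fold lower number from compound 2 to compound 3 (0.28 log units; within the scatter). The estimate for compound 3 is 15000 nM, with an expected range from 7000 nM to 32000 nM.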

Compound 3, half-maximal inhibitory concentration: 25600 nM
The estimate for compound 3 lay 1.7-fold (0.23 log units) below the measured number; the measured number falls inside the stated range.
By their numbers in this assay, from the lowest: compound 1; then compounds 3 and 2 (each within the scatter of the next).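

In this assay, hydroxy to methoxy at this oxygen on an aromatic ring gives a 1.1-fold lower number from compound 2 to compound 3 (0.04 log units; within the scatter) and so leaves compound 2 and compound 3 within the scatter of each other, a result the earlier pair could not show. The same kind of change at the other oxygen, read from a 2.4-fold higher number from compound 1 to compound 2 (0.38 log units; beyond the scatter), is beyond the scatter, so among these three compounds the two oxygens do not respond alike to methyl and hydrogen. Nothing available accounts for this difference between the two oxygens.

The compounds shown leave open whether this oxygen would remain as undemanding with an ethyl group, a longer chain or a carboxylic acid in place of the methyl, since methyl and hydrogen are the only two groups seen on it here. They also leave open whether the reading holds beyond this one cytotoxicity measurement on a single cell line, and whether it would persist on a core carrying different groups elsewhere, such as an amine in place of the remaining hydroxy.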